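Bromo Substitution Across Two Related Spiro-Linked Scaffolds

A few compounds are considered here, and "the series" means these few. Any claim that something is new, unique, unknown or untested is made for them only; others in the source may bear on it.

Compound 1 `COc1ccc(C2CC(c3ccc4ccccc4c3)=NN2C2=NC(=O)/C(=C3\C(=O)Nc4ccccc43)S2)cc1` and compound 2 `COc1ccc(C2CC(c3ccc4ccccc4c3)=NN2C2=NC(=O)/C(=C3\C(=O)Nc4ccc(Br)cc43)S2)cc1` differ in one place: bromo in place of hydrogen on an aromatic carbon. In a functional assay on cells (Cancer cell lines, Homo sapiens) for cytotoxicity, read by sulforhodamine B assay, with a stated time of 48 h (a lower number here means a stronger inhibitor of growth, a higher number a weaker inhibitor of growth), compound 1 gives 4030 nM, while compound 2 gives 220 nM; the step is an 18-fold lower number from compound 1 to compound 2 (1.26 log units; beyond the scatter). Compound 3 `CN(C)c1ccc(C2CC(c3ccccc3)=NN2C2=NC(=O)/C(=C3\C(=O)Nc4ccccc43)S2)cc1` carries a different core, and the difference between the two cores is not broken down here. In this assay compound 3 gives 25200 nM, the highest number among the three measured compounds.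

Compound 4 `CN(C)c1ccc(C2CC(c3ccccc3)=NN2C2=NC(=O)/C(=C3\C(=O)Nc4ccc(Br)cc43)S2)cc1` stands to compound 3 exactly as compound 2 stands to compound 1: bromo in place of hydrogen on an aromatic carbon. The change is the same, at the same place, and occurs twice among the compounds shown. Because the earlier step was an 18-fold lower number from compound 1 to compound 2 (1.26 log units; beyond the scatter), a lowering of a similar kind is expected for compound 4, though it rests on a single measured pair and a different core, so the expected step is tempered to an 8.4-fold lower number from compound 3 to compound 4 (0.92 log units; beyond the scatter). Compound 4 is therefore estimated to give 3000 nM in this assay, with an expected range from 800 nM to 12000 nM.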

Compound 4, concentration for total growth inhibition: 540 nM
Beside the measured number, compound 4's estimate is 5.6-fold (0.74 log units) above it, outside the stated range (below it).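

In this assay, bromo in place of hydrogen on an aromatic carbon again brings a large drop, a 47-fold lower number from compound 3 to compound 4 (1.67 log units; beyond the scatter), and the two steps agree in direction and, within the scatter, in size: the same change on two cores in this assay, an 18-fold lower number (1.26 log units; beyond the scatter) from compound 1 to compound 2 and a 47-fold lower number (1.67 log units; beyond the scatter) from compound 3 to compound 4, 2.5-fold (0.41 log units) apart, within the scatter of two such steps The change therefore carried over from the core of compound 1 to the core of compound 3, and the larger number for the second step should not be read as a stronger effect on that core. This rests on just two pairs, at one place and in one assay, so it shows neither why the bromo group lowers the number nor that a further core would respond in the same way.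

The compounds shown hold only hydrogen or bromo at this place, so it remains open whether chloro, a nitrile or a carboxylic acid there would lower the number to a similar extent. They also leave open how much each of the differences between the two cores contributes on its own.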